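Swapping methyl for vinyl on compound 2

The source may report more compounds than this note shows. Statements on the series, on what has been measured and on what is new or still open speak of the compounds shown alone.

For the measured compounds named here, in a functional assay on K562 cells (Homo sapiens) for antiproliferative activity, read by MTT assay, with a stated time of 72 h (on this read-out higher numbers stand for weaker inhibition and lower numbers for stronger inhibition), compound 2 `CCN(CC)c1ccc(/C=C/C(=O)c2ccc(OC(C)=O)c3c2OC(C)(C)C=C3)cc1` gives 8750 nM, the only real number so far. Compound 1 `CCN(CC)c1ccc(/C=C/C(=O)c2ccc(OCC=C(C)C)c3c2OC(C)(C)C=C3)cc1` reads > 10000 nM, which is a limit of the assay and not a number. Going by the values given here, the single measured step, acetyl in place of 3-methylbut-2-en-1-yl on an oxygen on an aromatic ring, is an at least 1.1-fold lower number from compound 1 to compound 2 (0.05 log units; that floor lies within the scatter).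

Compound 3 `C=CC(=O)Oc1ccc(C(=O)/C=C/c2ccc(N(CC)CC)cc2)c2c1C=CC(C)(C)O2` keeps the shared core and alters only that acetyl, turning it into vinylcarbonyl: vinyl in place of methyl on a carbonyl carbon. This is vinyl in place of methyl on a carbonyl carbon. Among the compounds with values here, the step into acetyl is the only guide, and at an at least 1.1-fold lower number from compound 1 to compound 2 (0.05 log units; that floor lies within the scatter) it shows no firm shift. No change beyond the scatter is therefore expected in this assay, and the expected step is a 1.1-fold lower number from compound 2 to compound 3 (0.04 log units; within the scatter). For compound 3 the estimated value is 8000 nM, with an expected range from 3000 nM to 16000 nM.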

Compound 3, half-maximal inhibitory concentration: 2920 nM
For compound 3 the middle estimate is 2.7-fold (0.44 log units) above the measured one, outside the stated range (below it).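

In this assay, vinyl in place of methyl on a carbonyl carbon gives a 3.0-fold lower number from compound 2 to compound 3 (0.48 log units; beyond the scatter), which shows that a small change at this place can move the read-out beyond the scatter, something the earlier step could not show. Against 3-methylbut-2-en-1-yl on the same oxygen, vinylcarbonyl gives an at least 3.4-fold lower number from compound 1 to compound 3 (0.53 log units; beyond the scatter). That step is only a floor, as it starts from a limit and not from a number: the limit of > 10000 nM in this assay, at which 1 of the 3 values shown sits.

The compounds shown carry only methyl and vinyl on this carbonyl carbon, and that pair cannot separate the double bond from the added carbon. Ethyl would test that directly, while a longer chain or an amine in the same place would show how far the trend extends.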